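Swapping pyrimidine for fluoropyridine: an expected solubility shift

The source may report more compounds than this note shows. Statements on the series, on what has been measured and on what is new or still open speak of the compounds shown alone.

Measured so far in a physicochemical assay for solubility, read by HPLC, using the shake flask method, measured as kinetic solubility, with a stated time of 2 h, at pH 7.4; a lower number here means a less soluble compound, a higher number a more soluble compound:
compound 1 `Cc1cc(NCc2ncccn2)n2nc(C)c(-c3ccccc3)c2n1`, 37900 nM;
compound 2 `Cc1cc(NCc2ccccn2)n2ncc(-c3ccccc3F)c2n1`, 5000 nM;
compound 3 `Cc1cc(NCc2ccccn2)n2ncc(-c3c(C)cccc3C)c2n1`, which gives only a limit, < 5000 nM.

Compound 1 holds the highest number of the two that are read, and compound 2 sits well below it, beyond the scatter. For the measured compounds named here, the one step that can be read, a number no higher from compound 2 to compound 3 (the limit leaves the size open), is of unknown size, since compound 3 sits at the limit of < 5000 nM in this assay, at which 1 of the 3 values shown sits.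

Compound 4 `Cc1cc(NCc2ccc(F)cn2)n2nc(C)c(-c3ccccc3)c2n1` differs from compound 1 by 5-fluoropyridin-2-yl in place of pyrimidin-2-yl on a saturated chain carbon bound to a nitrogen on an aromatic ring. No measured step changes this part of the molecule, so nothing shown bears directly on it. A modest fall in this assay is expected for compound 4, a 3.2-fold lower number from compound 1 to compound 4 (0.50 log units; beyond the scatter), with an estimate of 12000 nM between 4000 nM and 36000 nM.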

Compound 4, solubility: < 5000 nM
Compound 4 gave a limit, no number; the forecaster's own chance of this, stated with the estimate: 20%; middle value at least 2.4-fold (0.38 log units) from the limit.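

In this assay, for the compounds shown here, 5-fluoropyridin-2-yl in place of pyrimidin-2-yl gives an at least 7.5-fold lower number from compound 1 to compound 4 (0.87 log units; beyond the scatter) on this saturated chain carbon, the first measured step to change this part of the molecule. As far as these compounds go, the full size of that step stays unknown, since compound 4 gives a limit and not a number: the limit of < 5000 nM in this assay, at which 2 of the 4 values shown sit.

The fluorine and the change in ring nitrogens arrive together here, so the compounds shown cannot separate their shares of the step. From the compounds shown here alone, how a carboxylic acid or an amine on this ring would read also remains open.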